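Working notes: from compound 2 to compound 4

The source may hold more compounds than are shown below. What is called first, only, known or untested is meant among the compounds shown, and "the series" means these compounds.

Measured in a functional assay on PC-3 cells (Homo sapiens) for inhibition, read by MTT assay, with stated times of 18 h and 4 h; on this read-out lower numbers stand for stronger inhibition and higher numbers for weaker inhibition:
- compound 1 `CCCCCCCCOP(=O)(O)OCCSC(=S)N1CCCC1` gives > 100000 nM as a limit
- compound 2 `CCCCCCCCOP(=O)(O)OCCSC(=S)N1CCCCC1` gives > 100000 nM as a limit
- compound 3 `CCCCCCCCOP(=O)(O)OCCSC(=S)N1CCCCCC1` gives 56800 nM as a number

Compound 2 stands at > 100000 nM as a limit and not a number. Its position is the limit of > 100000 nM in this assay, at which 2 of the 3 values shown sit, and no more can be read from it.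

Compound 4 `CCCCCCOP(=O)(O)OCCSC(=S)N1CCCCC1` carries one change hydrogen in place of ethyl on a saturated chain carbon, six bonds along the chain from an oxygen on an unsaturated carbon that reads as hydrogen in place of ethyl on a saturated chain carbon, six bonds along the chain from an oxygen on an unsaturated carbon.

The step that the two limits leave unreadable from compound 1 to compound 2 and the step of an at least 1.7-fold lower number from compound 2 to compound 3 (0.24 log units; that floor lies within the scatter) alter only the group on a thiocarbonyl carbon. Neither touches the chain, so they bear on this change only indirectly. With compound 2 at a limit, no step beyond the scatter is expected in either direction in this assay and another limit is the likeliest result. The expected step is a step that the limit leaves unreadable from compound 2 to compound 4 and it is estimated as no readable change. For compound 4 the expected value is 130000 nM with an estimated range from 50000 nM to 300000 nM in this assay.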

Compound 4, half-maximal inhibitory concentration: > 100000 nM
Compound 4 ended at the assay's limit (the forecaster's own chance of this, stated with the estimate: 75%); the middle value is on the limit's open side.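

Compound 2 and compound 4 both stand at a limit and not at a number, so no step between them can be read: the limit of > 100000 nM in this assay, at which 3 of the 4 values shown sit.

The compounds shown leave open whether hydrogen in place of ethyl on the chain changes inhibition at all.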